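Back from Allyl to a Substituted Benzyl Ether

This account rests on a few compounds, and the source may have more. Where it says the series, first, only, none or still open, it means among the compounds named here.

Compound 1, `COc1ccc(C(OCc2ccccc2)c2cccc3ccccc23)c(OC)c1OC`, carries a benzyl group on the ether oxygen of the shared core. In a functional assay on MCF7 cells (Homo sapiens) for inhibition, read by sulforhodamine B assay, with a stated time of 48 h (a lower number here means a stronger inhibitor, a higher number a weaker inhibitor), compound 1 gives 14100 nM. Compound 2, `C=CCOC(c1ccc(OC)c(OC)c1OC)c1cccc2ccccc12`, carries an allyl group in its place. In this assay compound 2 gives > 20000 nM, which is a limit of the assay rather than a number. Compound 2 therefore stands only as a floor on the numbers shown (the limit of > 20000 nM in this assay, at which 1 of the 2 values shown sits). Among the measured compounds shown here, the one measured step, an at least 1.4-fold higher number from compound 1 to compound 2 (0.15 log units; that floor lies within the scatter), is the sole guide to how this position behaves.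

Compound 3, `COC(=O)c1ccc(COC(c2ccc(OC)c(OC)c2OC)c2cccc3ccccc23)cc1`, is not yet measured. It differs from compound 2 by 4-(methoxycarbonyl)phenyl in place of vinyl on a saturated chain carbon bound to an oxygen on a saturated carbon. This change runs opposite to the measured step, restoring an aromatic ring at the same place, now bearing an ester. Compound 1, with 14100 nM, is the nearest measured comparison. The step of an at least 1.1-fold lower number from compound 2 to compound 3 (0.07 log units; that floor lies within the scatter) is therefore expected to be a modest move toward a stronger inhibitor, if any change beyond the scatter occurs at all. Compound 3 is estimated at 17000 nM, between 7000 nM and 40000 nM, with a real chance that only a limit is reported again.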

Compound 3, half-maximal inhibitory concentration: > 20000 nM
Compound 3: a limit, no number; the forecaster's own chance of this, stated with the estimate: 45%; at least 1.1-fold (0.07 log units) between middle value and limit.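

The ester adds little to what compound 1 already showed, yet it does show that a restored aromatic ring does not by itself bring back a measured number. With methoxycarbonyl in place of hydrogen on an aromatic carbon, the comparison reads an at least 1.4-fold higher number from compound 1 to compound 3 (0.15 log units; that floor lies within the scatter), so the data cannot separate the benzyl ether from its ester-bearing form, and the true size of this change could be small or large. The steps that link compound 2 and compound 3 cannot be read, as both ends are limits, and what this position now shows is that two quite different groups, allyl and 4-(methoxycarbonyl)benzyl, end at the same limit in this assay: the limit of > 20000 nM in this assay, at which 2 of the 3 values shown sit.

Going by these compounds, how far compound 2 and compound 3 really lie from compound 1 stays open, as does whether any group at this place can give a stronger inhibitor than the plain benzyl of compound 1. Also open, on these data alone, is whether a carboxylic acid or an amine in place of the methoxycarbonyl on that ring, or a longer chain between the oxygen and the ring, would return a number rather than a limit.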